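The source may report more compounds than this note shows. Statements on the series, on what has been measured and on what is new or still open speak of the compounds shown alone.

In an ADME assay on microsomes from liver (Rattus norvegicus) for metabolic stability (on this read-out higher numbers stand for fast clearance and lower numbers for slow clearance), compound 1 (`Cc1ccc(NC(=O)c2cc(Oc3ccc(S(C)(=O)=O)cc3)cc(OC(C)C)c2)nc1`) gives 97 mL/min/kg. Compound 2 (`CC(C)Oc1cc(Oc2cnc(C(=O)N(C)C)nc2)cc(-c2nccc(=O)[nH]2)c1`) gives < 25.4 mL/min/kg, which is a limit of the assay and not a number. Compound 3 (`CCS(=O)(=O)c1ccc(Oc2cc(O[C@@H](C)CO)cc(-c3nccc(=O)[nH]3)c2)cc1`) gives < 25.4 mL/min/kg, also a limit. Compound 2 therefore stands at the limit of < 25.4 mL/min/kg in this assay, at which 2 of the 3 values shown sit, with no exact number to start from. Compound 4 (`CN(C)C(=O)c1ncc(Oc2cc(OC3CCCC3)cc(-c3nccc(=O)[nH]3)c2)cn1`) carries cyclopentyl in place of isopropyl on an oxygen on an aromatic ring. Going by the values given here, no measured pair shows this change, so the expectation is tentative: a modest rise in clearance in this assay, possibly no larger than the usual scatter. The expected change is an at least 1.2-fold higher number from compound 2 to compound 4 (0.10 log units; that floor lies within the scatter). For compound 4 the estimated clearance is 32 mL/min/kg, with an expected range of 16 mL/min/kg to 65 mL/min/kg.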

Compound 4, clearance: 106 mL/min/kg
Estimate against measurement, compound 4: 3.3-fold (0.52 log units) below; measured number above the stated range.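

In this assay, the change from isopropoxy to cyclopentyloxy gives an at least 4.1-fold higher number from compound 2 to compound 4 (0.62 log units; beyond the scatter), so the group on this oxygen matters to clearance on the shared core. Compound 2 sits at a limit of the assay, so the step gives only a floor and not its full size: the limit of < 25.4 mL/min/kg in this assay, at which 2 of the 4 values shown sit.

The compounds shown leave open whether the rise follows the ring itself or simply the larger number of carbons. A straight butyl chain or a cyclobutyl group on the same oxygen could help separate the two.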